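Swapping a Fluorophenyl for a Methylpyridinyl in Compound 2

The compounds below may be only part of what the source reports. "The series", "measured", "known", "first", "only" and "open" are said of these compounds alone.

Three compounds sharing one core have been examined in an assay on T-REx-293 cells for inhibition of potassium channel subfamily T member 1 (Homo sapiens), read by patch clamp; on this read-out lower numbers stand for stronger inhibition and higher numbers for weaker inhibition. Compound 1 `Cc1cccc(-c2noc([C@H](C)NC(=O)c3cc(C4CC4)n(C)n3)n2)c1` returns only a limit of the assay, > 30000 nM. Compound 2 `C[C@H](NC(=O)c1cc(C(F)(F)F)nn1C)c1nc(-c2cccc(F)c2)no1` gives 136 nM in this assay, the lowest of the two numbers that were actually measured. Compound 3 `C[C@@H](c1nc(-c2cccc(F)c2)no1)N(C)C(=O)c1cc(C(F)(F)F)nn1C` gives 6490 nM in this assay. Within the data shown here, the one step between measured compounds that differ in a single place is a 48-fold higher number from compound 2 to compound 3 (1.68 log units; beyond the scatter), a methyl in place of hydrogen on the amide-type nitrogen.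

Compound 4 `Cc1cc(-c2noc([C@H](C)NC(=O)c3cc(C(F)(F)F)nn3C)n2)ccn1` has not yet been measured in this assay. It differs from compound 2 by 2-methylpyridin-4-yl in place of 3-fluorophenyl on an aromatic carbon. Among the measured compounds shown here, no measured step touches this part of the structure: the single step available, which runs from compound 2 to compound 3, concerns the amide-type nitrogen rather than the aromatic group, so it offers no direct guide to the size or direction of the present change. Since the amide-type nitrogen of compound 4 keeps its hydrogen, no large step is expected, and the estimated step of a 2.9-fold higher number from compound 2 to compound 4 (0.47 log units; beyond the scatter) is expected to be modest. Compound 4 is therefore expected to give about 400 nM in this assay, with a plausible range from 100 nM to 2000 nM.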

Compound 4, half-maximal inhibitory concentration: 165 nM
Compound 4: middle estimate off by 2.4-fold (0.38 log units), on the high side; low and high end bracket the measured number.
By their numbers in this assay, from the lowest: compounds 2 and 4 (each within the scatter of the next); then compound 3. At a limit, above all of these: compound 1.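

Among these compounds, at this position, on an aromatic carbon of the five-membered aromatic ring with 2 nitrogen and 1 oxygen, 2-methylpyridin-4-yl in place of 3-fluorophenyl gives a 1.2-fold higher number from compound 2 to compound 4 (0.08 log units; within the scatter) in this assay, the first measured step at this place, and the two groups cannot be told apart on this read-out. Among the compounds shown here, the position thus takes a six-membered aromatic ring with 1 hetero atom and 1 hydrogen-bond acceptor in place of a ring of carbon only with no loss that can be read, whereas the one earlier step, at the amide-type nitrogen, was a 48-fold higher number from compound 2 to compound 3 (1.68 log units; beyond the scatter) and so gave no view of this part of the structure. Nothing in the data at hand bears on why these two groups read alike.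

From the compounds shown here alone, whether the methyl group or the ring nitrogen of 2-methylpyridin-4-yl counts on its own stays open, as does how a primary amine or a carboxylic acid on the aromatic ring would read at this place. Compound 1 gives > 30000 nM as a limit of the assay and differs from compound 2 in more than one place, so it offers no reading of this position.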